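The source may hold more compounds than are shown below. What is called first, only, known or untested is meant among the compounds shown, and "the series" means these compounds.

For the measured compounds named here, compound 2 `CC(C)CCn1c(N2CCN(C)CC2)nc2ccccc21` is the weaker of the two measured members: in a functional assay on ileum for inhibition of histamine H1 receptor (Cavia porcellus) (on this read-out lower numbers stand for stronger inhibition and higher numbers for weaker inhibition), compound 2 gives 1400 nM, and compound 1 `CCCCCCn1c(N2CCN(C)CC2)nc2ccccc21` gives 26 nM. Going by the values given here, the only step so far, a 54-fold higher number from compound 1 to compound 2 (1.73 log units; beyond the scatter), is large. Compound 3 `CCCC(C)n1c(N2CCN(C)CC2)nc2ccccc21` differs from compound 2 by 1-methylbutyl in place of isopentyl on an aromatic nitrogen; the atoms are the same, joined differently. Among the compounds with values here, no measured step matches branching at the attachment carbon, so the one known step is only a loose guide and the direction is open. For compound 3 the expected step is a 1.8-fold lower number from compound 2 to compound 3 (0.24 log units; within the scatter), with a wide band. The estimate for compound 3 in this assay is 800 nM, between 120 nM and 5000 nM.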

Compound 3, half-maximal inhibitory concentration: 1400 nM
Estimate against measurement, compound 3: 1.8-fold (0.24 log units) below, and the stated range covers the measured number.
By their numbers in this assay, from the lowest: compound 1; then compounds 2 and 3 (each within the scatter of the next).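

Rearranging the chain on the aromatic nitrogen from isopentyl to 1-methylbutyl gives no change at the digits printed from compound 2 to compound 3 (within the scatter) in this assay and so does not separate these two branched chains. Replacing hexyl with 1-methylbutyl gives a 54-fold higher number from compound 1 to compound 3 (1.73 log units; beyond the scatter) and shows that both branched chains shown stand well apart from the straight hexyl chain. Nothing available accounts for either step.
Open, on these data alone, is whether the low number of compound 1 is particular to hexyl. A straight pentyl or heptyl chain, a cyclohexyl group or a chain ending in an amine could each test that.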